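Swapping Bromophenyl for Pyridyl on the Amide Carbonyl

The source may report more compounds than this note shows. Statements on the series, on what has been measured and on what is new or still open speak of the compounds shown alone.

Three close relatives share one core and have been tested in a toxicity assay on THP-1 cells (Homo sapiens) for inhibition; a higher number here means that more compound is tolerated, a lower number that less compound is tolerated. Compound 1 `COc1ccc(-c2cnc(NC(=O)c3cccc([N+](=O)[O-])c3)n2C)cc1` carries a nitro group on its amide ring. In this assay compound 1 reaches only a limit of the test, > 100000 nM. Compound 2 `COc1ccc(-c2cnc(NC(=O)c3cccc(Br)c3)n2C)cc1` has bromo in place of nitro. In this assay compound 2 likewise stops at a limit, > 100000 nM. Compound 3 `Cn1c(-c2ccccc2)cnc1NC(=O)c1cccc(Br)c1` has hydrogen in place of methoxy. In this assay compound 3 again gives only a limit, > 50000 nM. All three numbers are limits, so the step that the two limits leave unreadable from compound 1 to compound 2 and the step that the two limits leave unreadable from compound 2 to compound 3 cannot be sized; what stands is that two compounds sit at the limit of > 100000 nM in this assay, at which 2 of the 3 values shown sit, and one at the limit of > 50000 nM in this assay, at which 1 of the 3 values shown sits.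

Compound 4 `COc1ccc(-c2cnc(NC(=O)c3ccncc3)n2C)cc1` is not yet measured. Relative to compound 2 the change is pyridin-4-yl in place of 3-bromophenyl on a carbonyl carbon. The two measured steps bear on it only in that neither moved a compound off its limit, and compound 2 itself stands at a limit rather than a number. The expected step is therefore a number no higher from compound 2 to compound 4 (the limit leaves the size open), nothing beyond the scatter, and most likely another limit. Compound 4 is estimated at 100000 nM, within 50000 nM to 200000 nM.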

Compound 4, half-maximal cytotoxic concentration: > 100000 nM
Compound 4 gave a limit, no number; the forecaster's own chance of this, stated with the estimate: 85%; the middle value lies on the limit itself.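

Compound 2 and compound 4 both stop at a limit of the test in this assay, so the step between them cannot be read and the swap of 3-bromophenyl for pyridin-4-yl has no size to report. The compounds shown leave open what concentration of any of them would reach half-maximal cytotoxicity.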